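The compounds below may be only part of what the source reports. "The series", "measured", "known", "first", "only" and "open" are said of these compounds alone.

Measured compounds in a functional assay on MCF7 cells (Homo sapiens) for cytotoxicity, read by MTT assay, with a stated time of 72 h; on this read-out lower numbers stand for stronger inhibition and higher numbers for weaker inhibition:
Compound 1 `Cc1nnc(SCc2cc(=O)c3ccccc3o2)s1` gives > 25000 nM, which is a limit of the assay.
Compound 2 `Nc1nnc(SCc2cc(=O)c3ccccc3o2)s1` gives > 25000 nM, again a limit.
Compound 3 `Nc1nnc(SCc2coc3ccccc3c2=O)s1` gives > 25000 nM, also a limit.

From compound 2 to compound 1 the change is methyl in place of amino on an aromatic carbon, and its step that the two limits leave unreadable from compound 2 to compound 1 cannot be read, since the limit of > 25000 nM in this assay, at which 3 of the 3 values shown sit, is where all values sit. How the cores of compound 2 and compound 3 differ is not broken down here. Compound 4 `Cc1nnc(SCc2coc3ccccc3c2=O)s1` has not yet been measured; it arises from compound 3 by methyl in place of amino on an aromatic carbon, the same change as from compound 2 to compound 1. Given that the step from compound 2 to compound 1 left no readable change, the step that the limit leaves unreadable from compound 3 to compound 4 is expected to be small, and compound 4 is estimated at 30000 nM, with most likely another limit.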

Compound 4, half-maximal inhibitory concentration: 6700 nM
Beside the measured number, compound 4's estimate is 4.5-fold (0.65 log units) above it; the measured number lies below the stated range.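

In this assay, methyl in place of amino gives an at least 3.7-fold lower number from compound 3 to compound 4 (0.57 log units; beyond the scatter), so on the core of compound 3 this change has a readable effect. Compound 3 gives > 25000 nM, which is a limit of the assay. The same change on the core of compound 2 cannot be read, so the data do not show whether the change acts alike on the two cores or differently: the limit of > 25000 nM in this assay, at which 3 of the 4 values shown sit.

The compounds shown leave open how a longer chain, such as ethyl, or a carboxylic acid would fare in place of the methyl of compound 4. They also leave open whether any such group would give a lower number than compound 4 does.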